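The compounds below may be only part of what the source reports. "The series", "measured", "known", "first", "only" and "open" are said of these compounds alone.

Compound 3 `COc1ccc2c(OCc3nnc4sc(-c5cc(F)c(F)c(F)c5)nn34)ccnc2c1` gives 403 nM in a functional assay on EBC-1 cells (Homo sapiens) for antiproliferative activity, with a stated time of 72 h (a lower number here means a stronger inhibitor, a higher number a weaker inhibitor), the highest of the three numbers seen; its nearest neighbour is compound 1 `COc1ccc2c(OCc3nnc4sc(-c5ccc[nH]5)nn34)ccnc2c1`, which gives 313 nM, and furthest is compound 2 `COc1ccc2c(OCc3nnc4sc(-c5cnn(C)c5)nn34)ccnc2c1`, which gives 88 nM. Compound 4 `COc1ccc2c(OCc3nnc4sc(-c5ccn(CC6CC6)c5)nn34)ccnc2c1` differs from compound 3 by 1-(cyclopropylmethyl)-1H-pyrrol-3-yl in place of 3,4,5-trifluorophenyl on an aromatic carbon. Among the compounds with values here, the steps that bear on it are a 1.3-fold higher number from compound 1 to compound 3 (0.11 log units; within the scatter) and a 4.6-fold higher number from compound 2 to compound 3 (0.66 log units; beyond the scatter): replacing the trifluorophenyl with a five-membered aromatic ring bearing nitrogen gave a lower or unchanged number, and the nitrogen-substituted ring of compound 2 gave the lowest. The step from compound 3 to compound 4 is therefore expected to be modest and downward, a 2.7-fold lower number from compound 3 to compound 4 (0.43 log units; beyond the scatter). Compound 4 is estimated at 150 nM, within 55 nM to 400 nM.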

Compound 4, half-maximal inhibitory concentration: 351 nM
Compound 4: middle estimate off by 2.3-fold (0.37 log units), on the low side; the measured number falls inside the stated range.
By their numbers in this assay, from the lowest: compound 2; then compounds 1, 4 and 3 (each within the scatter of the next).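

In this assay, a 1.1-fold lower number from compound 3 to compound 4 (0.06 log units; within the scatter) and a 1.1-fold higher number from compound 1 to compound 4 (0.05 log units; within the scatter) show that a pyrrole ring at this position, here 1-(cyclopropylmethyl)-1H-pyrrol-3-yl, does not separate from the 3,4,5-trifluorophenyl group or the 1H-pyrrol-2-yl group. Only 1-methyl-1H-pyrazol-4-yl stands apart, as a 4.0-fold higher number from compound 2 to compound 4 (0.60 log units; beyond the scatter) makes clear. Nothing available here accounts for this difference.

The compounds shown change ring and nitrogen substituent together, so a 1-methyl-1H-pyrrol-3-yl group or a 1-(cyclopropylmethyl)-1H-pyrazol-4-yl group would be needed to separate the two. From the compounds shown here alone, whether an amine or a carboxylic acid on a longer chain at that ring nitrogen is tolerated also remains open.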